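The compounds below may be only part of what the source reports. "The series", "measured", "known", "first", "only" and "open" are said of these compounds alone.

Compound 2, `CS(=O)(=O)c1ccc(N2CCc3c(OC4CCN(C(=S)Sc5ccccc5)CC4)ncnc32)c(F)c1`, stands lowest of the two numbers measured in a functional assay on CHO-K1 cells for agonist activity at Glucose-dependent insulinotropic receptor (Homo sapiens), read by a luciferase reporter, with a stated time of 5 h; a higher number here means that more compound is needed for the effect, a lower number that less compound is needed: compound 2 gives 12.6 nM, while compound 1, `CCCOC(=O)N1CCC(Oc2ncnc3c2CCN3c2ccc(S(C)(=O)=O)cc2F)CC1`, gives 79.4 nM in this assay. Within the data shown here, the one step between them, a 6.3-fold lower number from compound 1 to compound 2 (0.80 log units; beyond the scatter), came from putting a group of 9 heavy atoms with one aromatic ring on the ring amine nitrogen in place of an acyclic group of 6 heavy atoms.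

Compound 3, `CN(C)C(=O)CN1CCC(Oc2ncnc3c2CCN3c2ccc(S(C)(=O)=O)cc2F)CC1`, reverses that direction of change: a group of 6 heavy atoms (4 carbon, 1 nitrogen, 1 oxygen; no ring) in place of a group of 9 heavy atoms (7 carbon, 2 sulfur; one six-membered aromatic ring of carbon only), on an amine nitrogen in a ring. Among the measured compounds shown here, the entering (dimethylcarbamoyl)methyl is, in its count of heavy atoms and in lacking a ring, close to the group that compound 1 carried, though the atoms themselves differ, and no measured pair shows exactly this exchange. For the measured compounds named here, the only bearing step is the one from compound 1 to compound 2, and since compound 3 gives up the ring-bearing group that accompanied the lower number, the expectation is a step back toward the number of compound 1, estimated as a 4.8-fold higher number from compound 2 to compound 3 (0.68 log units; beyond the scatter). Compound 3 is therefore expected to give about 60 nM in this assay, within a range of 20 nM to 200 nM.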

Compound 3, half-maximal effective concentration: > 10000 nM
Compound 3: only a limit was reported (the forecaster's own chance of this, stated with the estimate: 3%); middle value at least 160-fold (2.22 log units) from the limit.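

The earlier pair showed only a 6.3-fold lower number from compound 1 to compound 2 (0.80 log units; beyond the scatter), whereas the new result shows that the group on this amine nitrogen can do far more than shift the number, with an at least 790-fold higher number from compound 2 to compound 3 (2.89 log units; beyond the scatter). Even against propoxycarbonyl, which also has no ring, (dimethylcarbamoyl)methyl brings an at least 120-fold higher number from compound 1 to compound 3 (2.10 log units; beyond the scatter), so the lack of a ring alone does not separate the high reading from the others among these compounds. The reading for compound 3 in this assay is a limit and not a number, so both steps give only a smallest possible size: the limit of > 10000 nM in this assay, at which 1 of the 3 values shown sits.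

The compounds shown leave open which part of (dimethylcarbamoyl)methyl goes with this limit, the methylene on the amine nitrogen or the dimethylamide at its end, and a dimethylcarbamoyl group or a propoxycarbonylmethyl group on the same nitrogen would tell these apart. They also leave open whether the sulfur atoms or the phenyl ring of the group in compound 2 go with its lower number, which a phenoxycarbonyl group in the same place would address.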